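Swapping the aryl group on the amine of compound 2

A few compounds are considered here, and "the series" means these few. Any claim that something is new, unique, unknown or untested is made for them only; others in the source may bear on it.

Compound 1 `CCCCCOC1=C(C(=O)c2ccccc2)C(c2ccc(Br)cc2)N(CCCn2ccnc2)C1=O` gives 10300 nM in a functional assay on NCI-H1299 cells (Homo sapiens) for antiproliferative activity, read by MTT assay, with a stated time of 72 h; a lower number here means a stronger inhibitor, a higher number a weaker inhibitor. Among the measured compounds shown here, compound 2 `Cc1ccc(NC2=C(C(=O)c3ccccc3)C(c3ccc(Br)cc3)N(CCCn3ccnc3)C2=O)cc1` gives 25800 nM in this assay, which is the higher of the two numbers measured so far, and the step of a 2.5-fold higher number from compound 1 to compound 2 (0.40 log units; beyond the scatter) puts the two apart by more than the usual scatter. Compound 3 `O=C(C1=C(Nc2ccccc2Br)C(=O)N(CCCn2ccnc2)C1c1ccc(Br)cc1)c1ccccc1` has not been measured; it differs from compound 2 only in one aryl group: 2-bromophenyl in place of 4-methylphenyl on an amine nitrogen. For the measured compounds named here, the single measured step replaced pentyloxy with an arylamino group on the ring carbon; no measured pair swaps one aryl for another on the amine nitrogen, so nothing here shows how such a swap moves the number. The expected step of a 1.2-fold lower number from compound 2 to compound 3 (0.07 log units; within the scatter) is therefore set close to no change, well inside the scatter. Compound 3 is estimated to give 22000 nM in this assay, between 8000 nM and 60000 nM.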

Compound 3, half-maximal inhibitory concentration: 15600 nM
The estimate for compound 3 lay 1.4-fold (0.15 log units) above the measured number, within the range that was stated.
By their numbers in this assay, from the lowest: compounds 1, 3 and 2 (each within the scatter of the next, the first and the last beyond it).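

In this assay, 2-bromophenyl in place of 4-methylphenyl on an amine nitrogen gives a 1.7-fold lower number from compound 2 to compound 3 (0.22 log units; within the scatter), so this first aryl-for-aryl swap at this place does not separate the two compounds. (2-Bromophenyl)amino in place of pentyloxy on the double-bonded ring carbon gives a 1.5-fold higher number from compound 1 to compound 3 (0.18 log units; within the scatter), which goes against any reading of the earlier step, a 2.5-fold higher number from compound 1 to compound 2 (0.40 log units; beyond the scatter), as applying to every arylamino group at this carbon. Nothing available explains these numbers.

The two aryl groups differ both in the atom they carry and in where it sits, so 4-bromophenyl or 2-methylphenyl on the same nitrogen would be needed to pull those two changes apart. From the compounds shown here alone, how a non-aromatic group on this nitrogen, such as cyclohexyl, would compare also remains open.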